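A Methylsulfanyl Group in Place of Methyl

The source may report more compounds than this note shows. Statements on the series, on what has been measured and on what is new or still open speak of the compounds shown alone.

Values in an ADME assay on S9 fraction from liver (Rattus norvegicus) for metabolic stability, read by LC-MS, using NADPH, with a stated time of 30 min; on this read-out lower numbers stand for a less stable compound and higher numbers for a more stable compound:
Compound 1 `CCCCCCCCc1ccc(OCC(=O)Cn2ncnn2)cc1`: < 5% (a limit)
Compound 2 `CCCCCCCCc1ccc(OCC(=O)Cn2nnc(C(=O)OC)n2)cc1`: < 5% (a limit)
Compound 3 `CCCCCCCCc1ccc(OCC(=O)Cn2nnnc2C)cc1`: 32%

Going by the values given here, compound 3 gives 32%, the only true number in the set. The values of the other two compounds are limits of the assay, and compound 3 alone stands clear of the limit of < 5% in this assay, at which 2 of the 3 values shown sit.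

The next compound, compound 4 `CCCCCCCCc1ccc(OCC(=O)Cn2nnnc2SC)cc1`, has methylsulfanyl in place of methyl on an aromatic carbon. Among the compounds with values here, two measured steps bear on this position: a number at least 27 percentage points higher from compound 1 to compound 3 (beyond the scatter) and a number at least 27 percentage points higher from compound 2 to compound 3 (beyond the scatter). Both end at the 5-methyl-1H-tetrazol-1-yl group, and the limits allow only a minimum size for each. Neither puts methylsulfanyl in place of methyl, so they show that changes at this group can move the read-out, but not which way the new group will take it. The step that the two limits leave unreadable from compound 1 to compound 2 adds nothing here.

With compound 3 at 32%, most of its standing in this assay is expected to be kept, with some risk of a larger loss. The expected step is a number 9 percentage points lower from compound 3 to compound 4 (within the scatter), an estimate that leans downward and stays small. For compound 4 the estimated value is 23%, with an expected range from 5% to 45%.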

Compound 4, percent of the compound remaining: 21%
Compound 4: the middle estimate sits 2 percentage points above what was measured; the measured number falls inside the stated range.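

In this assay, going by these compounds alone, the exchange of methyl for methylsulfanyl on the aromatic carbon gives the first direct reading of a change at this place: a number 11 percentage points lower from compound 3 to compound 4 (beyond the scatter). Methyl is therefore not the only group on this carbon that stands clear of the two compounds at the limit, since the 5-(methylsulfanyl)-1H-tetrazol-1-yl group also gives a number at least 16 percentage points higher from compound 2 to compound 4 (beyond the scatter) and a number at least 16 percentage points higher from compound 1 to compound 4 (beyond the scatter), although the 5-methyl-1H-tetrazol-1-yl group remains the better of the two by the first step. These two steps have only a minimum size because each starts from a value that is a limit and not a number: the limit of < 5% in this assay, at which 2 of the 4 values shown sit.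

The compounds shown leave open whether the lower number belongs to the sulfur atom or simply to a larger group, which a comparison with ethyl or methoxy on the same aromatic carbon could separate. They also leave open how an amine at this place would read, and whether the order of methyl and methylsulfanyl would hold on a core with a chain other than the octyl chain.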